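Series notes: methyl replacing methoxy, compound 2 to compound 3

The source may hold more compounds than are shown below. What is called first, only, known or untested is meant among the compounds shown, and "the series" means these compounds.

Among the measured compounds shown here, compound 2 `COc1ccc2nc(NC(=O)c3cn(-c4ccccc4)nc3-c3ccc(F)cc3)sc2c1` gives 12800 nM in a functional assay on PC-3 cells (Homo sapiens) for cytotoxicity, read by MTT assay, with a stated time of 72 h (a higher number here means a weaker inhibitor, a lower number a stronger inhibitor), the highest of the two numbers so far; its nearest neighbour is compound 1 `O=C(Nc1nc2ccc(F)cc2s1)c1cn(-c2ccccc2)nc1-c1ccc(F)cc1`, which in this assay gives 5260 nM. For the measured compounds named here, the only step recorded between these two, a 2.4-fold higher number from compound 1 to compound 2 (0.39 log units; beyond the scatter), concerns the same aromatic carbon that is changed next. Compound 3 `Cc1ccc2nc(NC(=O)c3cn(-c4ccccc4)nc3-c3ccc(F)cc3)sc2c1` differs from compound 2 by methyl in place of methoxy on an aromatic carbon. Going by the values given here, that earlier step is the one measurement bearing on this change, and it was modest; the methyl group itself has not been tried, so no direct comparison exists. The expectation is therefore a step of modest size or none beyond the scatter, a 1.6-fold lower number from compound 2 to compound 3 (0.20 log units; within the scatter), with the direction uncertain. Compound 3 is estimated at 8000 nM in this assay, with a range from 3000 nM to 22000 nM.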

Compound 3, half-maximal inhibitory concentration: 20500 nM
For compound 3 the middle estimate is 2.6-fold (0.41 log units) below the measured one; low and high end bracket the measured number.
By their numbers in this assay, from the lowest: compound 1; then compounds 2 and 3 (each within the scatter of the next).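

Replacing methoxy with methyl on this aromatic carbon gives no readable separation in this assay (a 1.6-fold higher number from compound 2 to compound 3 (0.20 log units; within the scatter)), so compound 2 and compound 3 stand level here. The fluoro group is now set apart from both of the other groups at this carbon, since the step to methyl (a 3.9-fold higher number from compound 1 to compound 3 (0.59 log units; beyond the scatter)) and the step to methoxy (a 2.4-fold higher number from compound 1 to compound 2 (0.39 log units; beyond the scatter)) both lie beyond the scatter, and compound 1 is the strongest of the three. Nothing on hand accounts for this difference between fluoro and the other two groups.

From the compounds shown here alone, compound 1 gives 5260 nM, and whether chloro, trifluoromethyl, an amine or a carboxylic acid on this carbon would give a lower number remains open. Also open, going by these compounds, is whether the same order of fluoro, methoxy and methyl holds in other cell lines.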